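This account rests on a few compounds, and the source may have more. Where it says the series, first, only, none or still open, it means among the compounds named here.

Measured compounds: compound 1 `CCCOC(=O)C1=C(C)N(C)C(=O)NC1c1cccs1` gives 9% in an assay on membranes from CHO cells for displacement of a labelled ligand from adenosine receptor A1 (Homo sapiens), read by scintillation counting, with a stated time of 60 min, tested at 1 uM; a higher number here means more inhibition at the concentration tested (going by the name of the read-out), a lower number less inhibition; compound 2 `CCCOC(=O)C1=C(C)N(C)C(=O)NC1c1ccsc1` gives 2%; compound 3 `CC1=C(c2ncc(C)o2)C(c2cccs2)NC(=O)N1` gives 21%.

Compound 2 differs from compound 1 by thiophen-3-yl in place of thiophen-2-yl on a saturated ring carbon, and this step is a number 7 percentage points lower from compound 1 to compound 2 (within the scatter). Compound 3 gives the highest number of the three. Compound 4 `CC1=C(c2ncc(C)o2)C(c2ccsc2)NC(=O)N1` is not yet measured; it differs from compound 3 by thiophen-3-yl in place of thiophen-2-yl on a saturated ring carbon. The difference between the core of compound 1 and the core of compound 3 is not broken down here. Around the place the surroundings differ: in compound 1 the saturated ring carbon is next to the ring atom that bears a propoxycarbonyl group, in compound 3 next to the ring atom that bears a 5-methyl-1,3-oxazol-2-yl group, so the change is the same kind of change, not the same. A step of about a number 7 percentage points lower from compound 3 to compound 4 (within the scatter) is expected, resting on the step of a number 7 percentage points lower from compound 1 to compound 2 (within the scatter) that stays within the scatter. Compound 4 is therefore estimated at 14%, expected between 2% and 26%.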

Compound 4, a percentage reported as inhibition, at one concentration (the size of the read-out at that concentration, not a potency): 34%
Estimate against measurement, compound 4: 20 percentage points below, outside the stated range (above it).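

In this assay, thiophen-3-yl in place of thiophen-2-yl on a saturated ring carbon gives a number 13 percentage points higher from compound 3 to compound 4 (beyond the scatter). Set beside the earlier step, the same change did not carry over between the two cores: the same change on two cores in this assay, a number 7 percentage points lower (within the scatter) from compound 1 to compound 2 and a number 13 percentage points higher (beyond the scatter) from compound 3 to compound 4, 20 percentage points apart, beyond the scatter of two such steps. For the compounds shown here, this shows that on these two cores the step on one was no guide to the step on the other, but it does not show which difference between the cores matters, and it says nothing about any further core.

Going by these compounds alone, only two pairs stand here, and each value is a reading at a single concentration, not a potency. Going by these compounds, whether the step would hold with a phenyl ring in place of the thiophene, or with a carboxylic acid in place of the propoxycarbonyl group, stays open.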